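Hydrazine-type substituent on the shared core: a working estimate

A few compounds are considered here, and "the series" means these few. Any claim that something is new, unique, unknown or untested is made for them only; others in the source may bear on it.

compound 1 `CCCNc1nn2c(=O)cc(C(F)(F)F)nc2s1`: 310 nM
compound 2 `CN(C)CCNc1nn2c(=O)cc(C(F)(F)F)nc2s1`: 3750 nM

In an ADME assay on cells for inhibition of Intestinal-type alkaline phosphatase (Homo sapiens), read by luminescence, with stated times of 7 min and 20 min (on this read-out lower numbers stand for stronger inhibition and higher numbers for weaker inhibition), compound 2 gives the highest of the two numbers, with compound 1 the nearest at a lower value. Going by the values given here, the one measured step, a 12-fold higher number from compound 1 to compound 2 (1.08 log units; beyond the scatter), is the only guide. Compound 3 `CN(N)c1nn2c(=O)cc(C(F)(F)F)nc2s1` carries amino(methyl)amino in place of (2-(dimethylamino)ethyl)amino on an aromatic carbon. This change removes the dimethylamino-bearing chain whose arrival, from compound 1 to compound 2, brought the large rise, but it does not restore the propylamino of compound 1, so the step is only loosely anchored. A partial return toward compound 1 is expected rather than a full one. For compound 3 the estimate in this assay is 900 nM, within 250 nM to 3500 nM, corresponding to an expected step of a 4.2-fold lower number from compound 2 to compound 3 (0.62 log units; beyond the scatter).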

Compound 3, half-maximal inhibitory concentration: 2220 nM
For compound 3 the middle estimate is 2.5-fold (0.39 log units) below the measured one; the range from low to high includes it.
By their numbers in this assay, from the lowest: compound 1; then compounds 3 and 2 (each within the scatter of the next).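

In this assay the exchange at this aromatic carbon gives a 1.7-fold lower number from compound 2 to compound 3 (0.23 log units; within the scatter) so amino(methyl)amino and (2-(dimethylamino)ethyl)amino cannot be told apart here, even though the substituent falls from 6 heavy atoms to 3. Set against propylamino, the same group gives a 7.2-fold higher number from compound 1 to compound 3 (0.85 log units; beyond the scatter) so losing the dimethylamino-bearing chain does not by itself recover the number of compound 1, which remains clearly apart from both compound 2 and compound 3. No measurement available here accounts for either step.

Open, going by these compounds, is whether a longer chain such as butylamino, or a cyclic amine such as morpholine, on this carbon would match or pass compound 1 at 310 nM in this series. Also open, on these data alone, is how a plain hydrazinyl group or a short ethylamino group would compare.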